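Propyl in Place of Hydrogen on the Core of Compound 3

The compounds below may be only part of what the source reports. "The series", "measured", "known", "first", "only" and "open" are said of these compounds alone.

Of the compounds shown here, three share a core and have been measured in a functional assay on the whole organism with Rattus norvegicus as the target, at a dose of 40 mg/kg by the intraperitoneal route; a higher number here means more inhibition at the dose given (going by the name of the read-out), a lower number less inhibition. Compound 1 `Cc1nc2c(OCc3ccccc3)ccc(C)n2c1C` gives 26%, compound 2 `Cc1ccn2c(C)c(C)nc2c1OCc1ccccc1` gives 92%, and compound 3 `Nc1cnc2c(OCc3ccccc3)cccn12` gives 32%. Compound 3 thus sits among the lower two of the three, within the scatter of compound 1, while compound 2 lies far above both.

Compound 4 `CCCc1nc2c(OCc3ccccc3)cccn2c1N` differs from compound 3 in one place: propyl in place of hydrogen on an aromatic carbon. Among the compounds with values here, no pair of measured compounds shows a comparable change, so the data give no step to lean on. Compound 4 is therefore expected to move only modestly, a step of a number 8 percentage points higher from compound 3 to compound 4 (within the scatter) in this assay. The estimate for compound 4 is 40%, between 15% and 70%.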

Compound 4, a percentage reported as inhibition, in the whole organism at one dose (the size of the read-out at that dose, not a potency): 31%
For compound 4 the middle estimate is 9 percentage points above the measured one, and the stated range covers the measured number.
By their numbers in this assay, from the lowest: compounds 1, 4 and 3 (each within the scatter of the next); then compound 2.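

In this assay, within the data shown here, propyl in place of hydrogen on this aromatic carbon, next to the ring atom that bears an amino group, gives a number 1 percentage points lower from compound 3 to compound 4 (within the scatter) and so offers the first reading of a change at this position. At this one dose, the position takes propyl with no shift beyond the usual scatter. No measurement at hand accounts for this result.

On these data alone, whether a longer chain, an amine or a carboxylic acid on this carbon would read the same stays open. So does whether propyl would behave alike on a core without the amino group.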